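Anilino in Place of Phenoxy: Expected Shift in Lipophilicity

The compounds below may be only part of what the source reports. "The series", "measured", "known", "first", "only" and "open" are said of these compounds alone.

Of the compounds shown here, two have been measured in a physicochemical assay for lipophilicity, using the shake flask method, in phosphate buffer, measured as octanol-water partition, with a stated time of 30 min, at pH 7.4; on this read-out lower numbers stand for lower lipophilicity and higher numbers for higher lipophilicity. Compound 1 `Fc1ccc2c(c1CNc1ncc(Oc3ccccc3)c3nncn13)CCO2` gives 3.5 in this assay, the higher of the two numbers. Its nearest neighbour, compound 2 `Cc1nn(C)cc1-c1cnc(NCc2c(F)ccc3c2CCO3)c2cn[nH]c(=O)c12`, gives 2.8 in this assay, a gap that lies beyond the usual scatter of repeated measurements. Going by the values given here, the two compounds differ in more than one place, so no single step between measured compounds can be drawn from them.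

Compound 3 `Fc1ccc2c(c1CNc1ncc(Nc3ccccc3)c3nncn13)CCO2` has not yet been measured in this assay. It differs from compound 1 in one place: anilino in place of phenoxy on an aromatic carbon. The anilino group brings one hydrogen-bond donor where the phenoxy group had none, while the count of heavy atoms and of acceptors stays the same. Among the compounds with values here, with no measured step of this kind on hand, the expectation rests on the structural change alone. A step from compound 1 to compound 3 of a number 0.50 log units lower from compound 1 to compound 3 (beyond the scatter) is expected, a modest fall that would lie beyond the scatter. Compound 3 is therefore estimated at 3 in this assay, with a range from 2.5 to 3.5.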

Compound 3, distribution coefficient: 3.3
For compound 3 the middle estimate is 0.30 log units below the measured one, within the range that was stated.
By their numbers in this assay, from the lowest: compound 2; then compounds 3 and 1 (each within the scatter of the next).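

Going by these compounds alone, at this place, on an aromatic carbon of a six-membered aromatic ring with 2 nitrogen, anilino in place of phenoxy gives in this assay a number 0.20 log units lower from compound 1 to compound 3 (within the scatter) and so provides the first single-place step. The anilino group brings 1 hydrogen-bond donor where the phenoxy group has 0, with the same count of heavy atoms and acceptors, yet compound 3 and compound 1 stand within the usual scatter of each other on this read-out, so this one exchange does not separate them. No measured evidence on hand bears on why the step has this size.

The compounds shown leave open whether other groups at this place would also stay within the scatter of compound 1, for example benzyl, a morpholine or a cyclohexylamino group, all of which would replace the aromatic ring or its link to the core. They also leave open what a carboxylic acid or a primary amine on the phenyl ring of compound 3 would do to the value in this assay at this same place.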